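Chloro in place of (methoxycarbonyl)amino: compound 4

The source may hold more compounds than are shown below. What is called first, only, known or untested is meant among the compounds shown, and "the series" means these compounds.

Going by the values given here, compound 1 `COC(=O)Nc1cc(-c2cc(Cl)c(OC[C@@](C)(N)CC(C)C)cn2)ccn1` gives 87% in an ADME assay on microsomes from liver (Mus musculus) for metabolic stability, read by LC-MS, using NADPH, with a stated time of 10 min, tested at 0.5 uM (on this read-out lower numbers stand for a less stable compound and higher numbers for a more stable compound), the second highest of the three numbers measured so far. Among the compounds with values here, compound 3 `COC(=O)Nc1cc(-c2ccc(OC[C@@](C)(N)CC(C)C)cn2)ccn1` gives 93% in the same assay, and the only single-point step in the set, a number 6 percentage points higher from compound 1 to compound 3 (within the scatter), lies within the scatter. Compound 2 `COC(=O)Nc1cc(-c2cnc(OC[C@@](C)(N)CC(C)C)cc2C)ccn1` gives 69%, the lowest number, beyond the scatter from compound 1. Compound 4 `CC(C)C[C@](C)(N)COc1cnc(-c2ccnc(Cl)c2)cc1Cl` is not yet measured; relative to compound 1 it differs by chloro in place of (methoxycarbonyl)amino on an aromatic carbon. Within the data shown here, no measured step touches this group, so nothing here says in which direction the number should move. The expected step of a number 7 percentage points lower from compound 1 to compound 4 (within the scatter) is therefore set at none beyond the scatter, with a wide range. Compound 4 is expected at 80%, between 50% and 97%.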

Compound 4, percent of the compound remaining: 92%
For compound 4 the middle estimate is 12 percentage points below the measured one; the range from low to high includes it.
By their numbers in this assay, from the lowest: compound 2; then compounds 1, 4 and 3 (each within the scatter of the next).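

Replacing (methoxycarbonyl)amino with chloro, on an aromatic carbon next to the ring nitrogen, gives in this assay a number 5 percentage points higher from compound 1 to compound 4 (within the scatter) and so this position tolerates the change on the core of compound 1. In this single pair, the larger group with its hydrogen-bond donor is not required to keep the number in this range. No measured evidence explains the result.

From the compounds shown here alone, it remains open whether an amine or a carboxylic acid at this place would give a comparable number. Going by these compounds, it is also open whether the same exchange would behave alike on the core of compound 2 or compound 3.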